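Compound 1 gains a carbonyl

The source may hold more compounds than are shown below. What is called first, only, known or untested is meant among the compounds shown, and "the series" means these compounds.

Within the data shown here, in a functional assay on A549 cells (Homo sapiens) for antiproliferative activity, read by MTT assay, with a stated time of 24 h (a higher number here means a weaker inhibitor, a lower number a stronger inhibitor), compound 1 `O=C(NNc1cccc(Cl)c1)c1ccc(NS(=O)(=O)c2cnc(O)nc2O)cc1` gives 7290 nM, the only actual number among the compounds measured so far. Compound 2 `Cc1ccccc1NNC(=O)c1ccccc1NS(=O)(=O)c1cnc(O)nc1O` is recorded only as a limit, > 20000 nM. Compound 3 `Cc1cccc(NNC(=O)c2ccccc2NS(=O)(=O)c2cnc(O)nc2O)c1` is likewise recorded only as a limit, > 20000 nM. Compound 4 `O=C(NNC(=O)c1cccc(Cl)c1)c1ccc(NS(=O)(=O)c2cnc(O)nc2O)cc1` has (3-chlorophenyl)carbonyl in place of 3-chlorophenyl on an amine nitrogen. Among the measured compounds shown here, the only measured step, a step that the two limits leave unreadable from compound 2 to compound 3, has no readable size and involves a different change, so it offers no guide here. No shift beyond the usual scatter is therefore expected in this assay, and neither direction is favoured. The expected change is a 1.1-fold higher number from compound 1 to compound 4 (0.04 log units; within the scatter). For compound 4, the estimated value is 8000 nM, with an expected range of 2500 nM to 20000 nM.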

Compound 4, half-maximal inhibitory concentration: 2290 nM
Compound 4: middle estimate off by 3.5-fold (0.54 log units), on the high side; the whole stated range lies above it.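

Adding a carbonyl on the amine nitrogen, which turns (3-chlorophenyl)amino into ((3-chlorophenyl)carbonyl)amino, gives a 3.2-fold lower number from compound 1 to compound 4 (0.50 log units; beyond the scatter) in this assay. Among these compounds, this is the first step of readable size here, and it shows that this position responds to change. The swap adds one hydrogen-bond acceptor, but these compounds cannot show why the number falls.

On these data alone, whether a sulfonyl or a longer chain at this place would do the same remains open. Compound 2 and compound 3 are recorded only as limits and differ from compound 4 in more than one place, so they cannot settle this: the limit of > 20000 nM in this assay, at which 2 of the 4 values shown sit.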